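Exchanging the cyclohexenyl group for a pentenyl chain

The source may hold more compounds than are shown below. What is called first, only, known or untested is meant among the compounds shown, and "the series" means these compounds.

Measured in an assay on CHO cells for antagonist activity at transient receptor potential cation channel subfamily V member 1 (Homo sapiens), read by FLIPR and calcium flux; on this read-out higher numbers stand for weaker inhibition and lower numbers for stronger inhibition:
compound 1 `CC(C(=O)NCc1ccc(C(F)(F)F)nc1C1CCC(F)(F)CC1)c1ccc(NS(C)(=O)=O)c(F)c1` gives 1.5 nM
compound 2 `CC(C(=O)NCc1ccc(C(F)(F)F)nc1C1=CCC(C(C)(C)C)CC1)c1ccc(NS(C)(=O)=O)c(F)c1` gives 0.2 nM

Compound 2 stands lowest of the two numbers; the step of a 7.5-fold lower number from compound 1 to compound 2 (0.88 log units; beyond the scatter) lies beyond the scatter. Compound 3 `CCC/C=C/c1nc(C(F)(F)F)ccc1CNC(=O)C(C)c1ccc(NS(C)(=O)=O)c(F)c1` differs from compound 2 by pent-1-en-1-yl in place of 4-(tert-butyl)cyclohex-1-en-1-yl on an aromatic carbon. Going by the values given here, the one measured step that bears on this position, a 7.5-fold lower number from compound 1 to compound 2 (0.88 log units; beyond the scatter), shows that the group there moves the number in this assay by a modest amount; the entering pent-1-en-1-yl group, with no ring, is expected to move it back toward compound 1. Compound 3 is therefore estimated at 1.2 nM, within 0.3 nM to 5 nM, an expected step of a 6.0-fold higher number from compound 2 to compound 3 (0.78 log units; beyond the scatter).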

Compound 3, inhibition constant: 0.9 nM
Compound 3: middle estimate off by 1.3-fold (0.12 log units), on the high side; measured number inside the range.
By their numbers in this assay, from the lowest: compound 2; then compounds 3 and 1 (each within the scatter of the next).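

In this assay, pent-1-en-1-yl in place of 4-(tert-butyl)cyclohex-1-en-1-yl on this carbon next to the ring nitrogen weakens inhibition (a 4.5-fold higher number from compound 2 to compound 3 (0.65 log units; beyond the scatter)). Even so, the group with no ring is not separated from 4,4-difluorocyclohexyl (a 1.7-fold lower number from compound 1 to compound 3 (0.22 log units; within the scatter)), so a ring is not required to match compound 1. No measurement at hand explains either step.

The compounds shown leave open whether the chain's double bond matters, which a saturated pentyl chain would test. They also leave open how a longer chain or an amine such as piperidine would fare here.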